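Sulfonamide aryl swap on the shared core

The source may hold more compounds than are shown below. What is called first, only, known or untested is meant among the compounds shown, and "the series" means these compounds.

Two compounds of the series carry a value in an assay on Sf9 cells for inhibition of mitogen-activated protein kinase kinase kinase 20 (Homo sapiens), read by ADP-Glo, with a stated time of 30 min; a lower number here means a stronger inhibitor, a higher number a weaker inhibitor. Compound 1 `COc1n[nH]c2ncc(-c3nc(-c4c(F)ccc(NS(=O)(=O)c5cccc(Cl)c5)c4F)no3)cc12` gives 29 nM in this assay. Compound 2 `COc1n[nH]c2ncc(-c3cn(-c4c(F)ccc(NS(=O)(=O)c5cccc(Br)c5)c4F)nn3)cc12` gives 2.1 nM in this assay, the lowest of the two numbers; the gap to compound 1 lies beyond the scatter. Among the measured compounds shown here, no single-point step between measured compounds is available, so the series offers no direct precedent for what a change of the aryl group on the sulfonyl sulfur does.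

Compound 3 `COc1n[nH]c2ncc(-c3cn(-c4c(F)ccc(NS(=O)(=O)c5cccc6ccccc56)c4F)nn3)cc12` is not yet measured. It differs from compound 2 in one place: naphthalen-1-yl in place of 3-bromophenyl on a sulfonyl sulfur. The sulfonamide nitrogen, the difluorinated ring and the rest of the shared core are kept.

For the measured compounds named here, with no measured step of this kind on record, the expected step from compound 2 to compound 3 in this assay is small, a 1.4-fold higher number from compound 2 to compound 3 (0.15 log units; within the scatter), in no direction beyond the scatter. Compound 3 is expected to give about 3 nM in this assay, with a range from 0.8 nM to 12 nM.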

Compound 3, half-maximal inhibitory concentration: 4.2 nM
For compound 3 the middle estimate is 1.4-fold (0.15 log units) below the measured one; the range from low to high includes it.
By their numbers in this assay, from the lowest: compounds 2 and 3 (each within the scatter of the next); then compound 1.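

In this assay, the change on the sulfonyl sulfur now has its first single-point reading: naphthalen-1-yl in place of 3-bromophenyl gives a 2.0-fold higher number from compound 2 to compound 3 (0.30 log units; within the scatter). This position on the sulfonyl sulfur therefore accepts either one or 2 six-membered aromatic rings of carbon only, and the bromine can be lost without a shift beyond the scatter, at least for this single pair with the sulfonamide nitrogen, the difluorinated ring and the rest of the shared core kept. Nothing available explains why these two groups read alike in this assay.

A single step between two aryl groups does not define how much variation the position will accept, and the compounds shown do not tell whether a non-aromatic group such as cyclohexyl or a longer chain such as n-butyl would read like these two groups. Also open, as far as these compounds go, is whether a phenyl ring bearing an amine or a carboxylic acid would stay within the scatter of compound 2, and whether the same swap would read alike on the core of compound 1.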